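The source may hold more compounds than are shown below. What is called first, only, known or untested is meant among the compounds shown, and "the series" means these compounds.

Of the compounds shown here, two have been tested so far in an ADME assay on HepG2 2.2.15 cells (Homo sapiens) for cytotoxicity; on this read-out higher numbers stand for lower toxicity in this test and lower numbers for higher toxicity in this test. Compound 1 `O=c1c(CCO)c(-c2ccccc2Cl)c2cc(Cl)ccc2n1-c1c(F)cccc1F` gives > 2300000 nM, which is a limit of the assay and not a number. Within the data shown here, compound 2 `CC(C)C(=O)OCCc1c(-c2ccccc2Cl)c2cc(Cl)ccc2[nH]c1=O` gives 62000 nM, the only exact number available on this read-out, and it is therefore the single firm reference point. Compound 3 `O=C(O)CCCC(=O)OCCc1c(-c2ccccc2Cl)c2cc(Cl)ccc2[nH]c1=O` has not yet been tested in this assay. It differs from compound 2 in one place, with 3-carboxypropyl in place of isopropyl on a carbonyl carbon. Among the measured compounds shown here, no measured pair of compounds shows what a swap of this kind does. A modest move towards higher numbers, meaning somewhat lower toxicity in this test, is expected, and the estimated size is a 2.4-fold higher number from compound 2 to compound 3 (0.38 log units; beyond the scatter). For compound 3 the expected value is 150000 nM, with an estimated range of 40000 nM to 600000 nM.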

Compound 3, half-maximal cytotoxic concentration: 110000 nM
The estimate for compound 3 lay 1.4-fold (0.13 log units) above the measured number, within the range that was stated.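

In this assay, putting 3-carboxypropyl in place of isopropyl on a carbonyl carbon gives a 1.8-fold higher number from compound 2 to compound 3 (0.25 log units; within the scatter). Among these compounds, this is the first pair that differs in one place, and it shows that a chain of 6 heavy atoms ending in a carboxylic acid, in place of a group of 3 heavy atoms, leaves no difference that can be told from the scatter. The read-out still has room for much higher numbers, as compound 1 shows with a limit of the assay rather than a number: the limit of > 2300000 nM in this assay, at which 1 of the 3 values shown sits.

From the compounds shown here alone, whether the acid or the chain length matters more stays open, and a plain longer alkyl chain or an amine at the chain end would help separate the two. Also open, going by these compounds, is whether a phenyl ring on this carbonyl carbon would move the number beyond the scatter.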